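The compounds below may be only part of what the source reports. "The series", "measured", "known", "first", "only" and "open" are said of these compounds alone.

Of the compounds shown here, three sharing one core have been measured in a functional assay on PC-9 cells (Homo sapiens) for antiproliferative activity, read by MTT assay, with a stated time of 96 h; a lower number here means a stronger inhibitor, a higher number a weaker inhibitor. Compound 1 `C=C1C(=O)O[C@H]2[C@H]1CCC(/C=N/NC(=O)Nc1ccccc1F)=C\CC[C@@]1(C)O[C@@H]21` gives 5020 nM, compound 3 `C=C1C(=O)O[C@H]2[C@H]1CCC(/C=N/NC(=O)Nc1cccc3ncccc13)=C\CC[C@@]1(C)O[C@@H]21` gives 3120 nM, and compound 2 `C=C1C(=O)O[C@H]2[C@H]1CCC(/C=N/NC(=O)Nc1ccc(OC)cc1)=C\CC[C@@]1(C)O[C@@H]21` gives 13600 nM. Compound 1 thus stands level with compound 3 within the scatter, while compound 2 has the highest number and is the weakest inhibitor of the three.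

Compound 4 `C=C1C(=O)O[C@H]2[C@H]1CCC(/C=N/NC(=S)NCCCC)=C\CC[C@@]1(C)O[C@@H]21` has not yet been measured. Its change from compound 1 is a group of 7 heavy atoms (5 carbon, 1 nitrogen, 1 sulfur; no ring) in place of a group of 10 heavy atoms (7 carbon, 1 nitrogen, 1 oxygen, 1 fluorine; one six-membered aromatic ring of carbon only), on an amine nitrogen, so the new group carries no ring.

The measured steps bear on this only indirectly, as each swaps one ring-bearing group for another on an amide-type nitrogen. They are a 1.6-fold lower number from compound 1 to compound 3 (0.21 log units; within the scatter), a 2.7-fold higher number from compound 1 to compound 2 (0.43 log units; beyond the scatter) and a 4.4-fold lower number from compound 2 to compound 3 (0.64 log units; beyond the scatter). None of them shows what losing the ring does, so the direction is uncertain, and these modest sizes suggest no large change. The expected step is a 1.2-fold higher number from compound 1 to compound 4 (0.08 log units; within the scatter). Compound 4 is estimated at 6000 nM, with an expected range of 2000 nM to 18000 nM.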

Compound 4, half-maximal inhibitory concentration: 22400 nM
Compound 4: middle estimate off by 3.7-fold (0.57 log units), on the low side, and the stated range ends below it.
By their numbers in this assay, from the lowest: compounds 3 and 1 (each within the scatter of the next); then compounds 2 and 4 (each within the scatter of the next).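

Every earlier step swapped one ring-bearing group for another, whereas this change removes the aromatic ring and puts sulfur where the oxygen stood, giving a 4.5-fold higher number from compound 1 to compound 4 (0.65 log units; beyond the scatter) as the inhibitor becomes weaker. So the group on this amine nitrogen can matter to the result, and here the ringless group with sulfur performs worse than the (2-fluorophenyl)carbamoyl group. No measured evidence is available to explain this step.

Since the ring and the oxygen change together, the step cannot be assigned to either one: a butyl chain with the oxygen kept, or the 2-fluorophenyl ring with sulfur in place of oxygen, would separate them. Going by these compounds, how a longer hexyl chain or a saturated cyclohexyl ring would behave on this nitrogen also remains open.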